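The source may report more compounds than this note shows. Statements on the series, on what has been measured and on what is new or still open speak of the compounds shown alone.

Measured so far:
compound 1, `COc1ccc(-n2nc(C(N)=O)nc2-c2cc(OC)c(OC)c(OC)c2)cc1`: 92%
compound 2, `COc1ccc(-n2nc(C(=O)Nc3ccccc3OC)nc2-c2cc(OC)c(OC)c(OC)c2)cc1`: 38%

Both were tested in a functional assay on the whole organism for inhibition, with Rattus norvegicus as the target, read by paw edema, with stated times of 30 min and 3 h, at a dose of 0.28 mmol/kg by the oral route; on this read-out higher numbers stand for more inhibition at the one dose given (going by the name of the read-out) and lower numbers for less inhibition. Of these two numbers compound 2 stands lowest; its nearest neighbour is compound 1, which sits higher by a number 54 percentage points lower from compound 1 to compound 2 (beyond the scatter), a large drop when 2-methoxyphenyl replaces hydrogen on an amide-type nitrogen.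

The next compound, compound 3 `COc1ccc(-n2nc(C(=O)Nc3ccc(C)cc3)nc2-c2cc(OC)c(OC)c(OC)c2)cc1`, keeps the shared core of compound 2 and changes only the group on that amide-type nitrogen: 4-methylphenyl in place of 2-methoxyphenyl on an amide-type nitrogen.

Among the compounds with values here, the single measured step, from compound 1 to compound 2, does not bear closely on this change. It replaced hydrogen with an aromatic ring, whereas here one aromatic ring gives way to another and the amide-type nitrogen stays substituted. Within the data shown here, no measured pair shows what exchanging one such ring for another does, so the outlook rests on compound 2 alone. A step of no clear direction, likely within the scatter, is therefore expected. The estimated step is a number 2 percentage points higher from compound 2 to compound 3 (within the scatter). Compound 3 is expected to give about 40% in this assay, within 15% to 65%.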

Compound 3, a percentage reported as inhibition, in the whole organism at one dose (the size of the read-out at that dose, not a potency): 77%
Estimate against measurement, compound 3: 37 percentage points below; measured number outside the range, above it.
By their numbers in this assay, from the lowest: compound 2; then compound 3; then compound 1.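

In this assay, within the data shown here, what matters on the amide-type nitrogen is not only that an aromatic ring is present but which ring it is: 4-methylphenyl in place of 2-methoxyphenyl gives a number 39 percentage points higher from compound 2 to compound 3 (beyond the scatter), so the fall seen earlier does not hold for every such ring. Measured against the amide with its hydrogen in place, 4-methylphenyl gives a number 15 percentage points lower from compound 1 to compound 3 (beyond the scatter), a much smaller fall than the one 2-methoxyphenyl gave, a number 54 percentage points lower from compound 1 to compound 2 (beyond the scatter), and a ring at this position can therefore keep much of the inhibition at this single dose. Nothing at hand accounts for the gap between these two rings.

As far as these compounds go, the two rings differ both in the group they carry and in the number in their names, so it remains open which of these matters; 2-methylphenyl and 4-methoxyphenyl would separate the two. Also open, from the compounds shown here alone, is how a group without a ring, such as a plain methyl or a longer carbon chain, would behave on this nitrogen.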